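Fluoro to isopropyl on the aryl ring of compound 2

The compounds below may be only part of what the source reports. "The series", "measured", "known", "first", "only" and "open" are said of these compounds alone.

Measured compounds:
compound 1, `Fc1ccc([C@@H]2NCCOC23COC[C@H](c2ccccc2)C3)cc1`: 99 nM
compound 2, `COc1ccc(F)cc1[C@H]1COCC2(C1)OCCN[C@H]2c1ccc(F)cc1`: 10 nM

In an assay on CHO cells for displacement of a labelled ligand from Substance-P receptor (Homo sapiens) (a higher number here means a weaker inhibitor, a lower number a stronger inhibitor), compound 2 gives 10 nM and holds the lowest number of the two measured compounds; compound 1 gives 99 nM. Among the compounds with values here, the only measured step, a 9.9-fold lower number from compound 1 to compound 2 (1.00 log units; beyond the scatter), came from a 5-fluoro-2-methoxyphenyl in place of phenyl on a saturated ring carbon.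

Compound 3, `COc1ccc(C(C)C)cc1[C@H]1COCC2(C1)OCCN[C@H]2c1ccc(F)cc1`, differs from compound 2 by isopropyl in place of fluoro on an aromatic carbon, on an aromatic carbon of a six-membered aromatic ring of carbon only, para to a methoxy group. Within the data shown here, no measured step changes a substituent on that aromatic ring, so the measured step gives no direct guide. Compound 3 is therefore expected to stay near compound 2, with a 2.0-fold higher number from compound 2 to compound 3 (0.30 log units; within the scatter) as the estimated step and a wide range. The estimate for compound 3 in this assay is 20 nM, between 5 nM and 80 nM.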

Compound 3, half-maximal inhibitory concentration: 2.8 nM
The estimate for compound 3 lay 7.1-fold (0.85 log units) above the measured number; the whole stated range lies above it.
By their numbers in this assay, from the lowest: compound 3; then compound 2; then compound 1.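

In this assay, the aromatic carbon para to a methoxy group tolerates more than a single atom: isopropyl in place of fluoro gives a 3.6-fold lower number from compound 2 to compound 3 (0.55 log units; beyond the scatter). The earlier step changed the whole aryl group at once, whereas this one isolates a single substituent and shows that fluoro is not needed at this position to keep the number low. The larger group, with its 3 heavy atoms against 1, goes with a stronger inhibitor in this one pair, and nothing measured here explains the gain.

The compounds shown leave open whether the gain follows the size of the carbon group, which an ethyl, a tert-butyl or a cyclopropyl would test. They also leave open whether a hydroxyl or an amine would be tolerated at this position.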